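The compounds below may be only part of what the source reports. "The series", "measured", "known", "first", "only" and "open" are said of these compounds alone.

For the measured compounds named here, compound 3 `CC(C)C(=O)NC(C(=O)N1CCC(c2ccc(Cl)cc2)CC1)C(C)C` sits at the top of the numbers measured so far: in an assay on THP-1 cells for displacement of a labelled ligand from C-C chemokine receptor type 1 (Homo sapiens) (on this read-out lower numbers stand for stronger inhibition and higher numbers for weaker inhibition), compound 3 gives 388 nM, the highest of the three. Compound 1 `Cc1ccc(CCC(=O)N[C@@H](C(=O)N2CCC(c3ccc(Cl)cc3)CC2)C(C)C)cc1` gives 105 nM in this assay, and compound 2 `CC(C)[C@@H](NC(=O)c1cc2ccccc2s1)C(=O)N1CCC(c2ccc(Cl)cc2)CC1` gives 58 nM, each well beyond the scatter from compound 3.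

Compound 4 `CC(C)C(NC(=O)Oc1ccccc1)C(=O)N1CCC(c2ccc(Cl)cc2)CC1` differs from compound 3 in one place: phenoxy in place of isopropyl on a carbonyl carbon. The change sits on the same carbonyl carbon that carries the variable group in compounds 1 and 2, each of which holds an aromatic ring there and shows a lower number than compound 3. Going by the values given here, the only measured step at that carbonyl, a 1.8-fold lower number from compound 1 to compound 2 (0.26 log units; within the scatter), swaps one aromatic group for another and stays within the scatter, so it gives no sign of which aromatic group is better, only that both give lower numbers than the isopropyl of compound 3. Compound 4 is therefore expected to move in the same direction, with an expected step of a 3.0-fold lower number from compound 3 to compound 4 (0.47 log units; beyond the scatter). The estimate for compound 4 in this assay is 130 nM, within a range from 50 nM to 350 nM.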

Compound 4, half-maximal inhibitory concentration: 265 nM
Compound 4: the middle estimate sits 2.0-fold (0.31 log units) below what was measured; the measured number falls inside the stated range.
By their numbers in this assay, from the lowest: compounds 2 and 1 (each within the scatter of the next); then compounds 4 and 3 (each within the scatter of the next).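

In this assay the change to phenoxy gives a 1.5-fold lower number from compound 3 to compound 4 (0.17 log units; within the scatter) and cannot be told apart from no change at all. An aromatic ring on this carbonyl carbon therefore does not by itself bring the number down to those of compounds 1 and 2: compound 4 goes against the pattern those two suggested, and its value stays level with that of compound 3.

What the compounds shown leave open is whether the oxygen joining the ring to the carbonyl carbon matters, or the ring itself: a phenyl bonded straight to that carbon, or a phenylamino group there, would test this directly. A benzyloxy group in the same place would show whether one more carbon before the ring changes the number.

Nothing given here explains why phenoxy and isopropyl read so alike.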